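Swapping the Chain Substituent on the Shared Core

This account rests on a few compounds, and the source may have more. Where it says the series, first, only, none or still open, it means among the compounds named here.

Compound 1 `Cc1cn2cccc(OCc3ccccc3)c2n1`: 62%
Compound 2 `Cc1nc2c(OCc3ccccc3)cccn2c1Cl`: 93%
Compound 3 `COC(=O)Cc1c(C)nc2c(OCc3ccccc3)cccn12`: 23%

In a functional assay on the whole organism with Rattus norvegicus as the target, with a stated time of 4 h, at a dose of 40 mg/kg by the intraperitoneal route (on this read-out lower numbers stand for less inhibition and higher numbers for more inhibition at the one dose given (going by the name of the read-out)), compound 3 stands lowest of the three. The step of a number 39 percentage points lower from compound 1 to compound 3 (beyond the scatter) and the step of a number 70 percentage points lower from compound 2 to compound 3 (beyond the scatter) are both large falls, seen when (methoxycarbonyl)methyl stands on the aromatic carbon where compound 1 carries hydrogen and compound 2 carries chloro. Compound 4 `Cc1nc2c(OCc3ccccc3)cccn2c1COC(=O)C(C)(C)C` keeps a chain on that carbon but changes its end: ((tert-butyl)carbonyl)oxy in place of methoxycarbonyl on a saturated chain carbon bound to an aromatic carbon. Going by the values given here, no measured pair carries this exchange, so the two steps into compound 3 only fix the starting point in this assay and say nothing about the new group. The step of a number 12 percentage points higher from compound 3 to compound 4 (beyond the scatter) is therefore estimated to be modest, with its direction left open by the data. Compound 4 is estimated at 35%, within a range from 10% to 65%.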

Compound 4, a percentage reported as inhibition, in the whole organism at one dose (the size of the read-out at that dose, not a potency): 48%
The estimate for compound 4 lay 13 percentage points below the measured number; measured number inside the range.
By their numbers in this assay, from the lowest: compound 3; then compound 4; then compound 1; then compound 2.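

In this assay the end of the chain on this carbon proves to matter: ((tert-butyl)carbonyl)oxy in place of methoxycarbonyl gives a number 25 percentage points higher from compound 3 to compound 4 (beyond the scatter) and so shows that the fall seen with compound 3 is not fixed for every chain here. The chain still stands below both hydrogen and chloro, with a number 14 percentage points lower from compound 1 to compound 4 (beyond the scatter) and with a number 45 percentage points lower from compound 2 to compound 4 (beyond the scatter) as well. No evidence at hand explains these steps. Open, as far as these compounds go, is how a carboxylic acid, an amine or a longer chain on this carbon would read, and whether bromo would match chloro.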